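The compounds below may be only part of what the source reports. "The series", "measured", "known", "first", "only" and "open" are said of these compounds alone.

In a functional assay on HUVEC cells (Homo sapiens) for inhibition, with stated times of 2 h and 72 h (on this read-out higher numbers stand for weaker inhibition and lower numbers for stronger inhibition), compound 1 `COc1cc2nccc(Oc3ccc4c(NC(=O)c5cccc(C)c5)nn(C)c4c3)c2cc1OC` gives > 1000 nM, a limit of the assay rather than a number. Compound 2 `COc1cc2nccc(Oc3ccc4c(NCc5ccccc5)nn(C)c4c3)c2cc1OC` gives > 1000 nM, likewise only a limit. Compound 3 `COc1cc2nccc(Oc3ccc4c(Nc5ccccc5)nn(C)c4c3)c2cc1OC` gives > 1000 nM, again a limit and not a number.

Compound 3 therefore stands where every measured compound stands: at the limit of > 1000 nM in this assay, at which 3 of the 3 values shown sit. The unmeasured compound 4 `COc1ccc(C(=O)Nc2nn(C)c3cc(Oc4ccnc5cc(OC)c(OC)cc45)ccc23)cc1` differs from compound 3 in a single place: (4-methoxyphenyl)carbonyl in place of phenyl on a nitrogen on an aromatic ring. The steps that touch the phenyl of compound 3, a step that the two limits leave unreadable from compound 2 to compound 3 and a step that the two limits leave unreadable from compound 1 to compound 3, carry no readable size, and the step that the two limits leave unreadable from compound 1 to compound 2 is equally unreadable. Among the compounds with values here, no measured compound shows a move off the limit. The step that the limit leaves unreadable from compound 3 to compound 4 is thus expected to be small, with compound 4 most likely resting at the limit once more. Compound 4 is estimated at 2000 nM, within 700 nM to 8000 nM.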

Compound 4, half-maximal inhibitory concentration: > 1000 nM
Compound 4: only a limit was reported (the forecaster's own chance of this, stated with the estimate: 70%); the middle value lies beyond the limit too.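

Within the data shown here, no step between compound 4 and compound 1, compound 2 or compound 3 can be read, because all of them rest at a limit and not at a number: the limit of > 1000 nM in this assay, at which 4 of the 4 values shown sit. On these data alone, whether swapping the groups on the nitrogen changes inhibition at all, and by how much, stays open.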